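One Aryl Group Exchanged, Activity Expected to Hold

The compounds below may be only part of what the source reports. "The series", "measured", "known", "first", "only" and "open" are said of these compounds alone.

Compound 1 `Nc1ccccc1NC(=O)c1ccc(CSC(=S)N2CCN(c3ccc(F)cc3)CC2)cc1` was tested in a functional assay on A-375 cells (Homo sapiens) for antiproliferative activity, read by CCK-8 assay, with a stated time of 72 h, tested at 8 uM (a lower number here means a weaker effect, a higher number a stronger effect of the compound at the concentration tested), where compound 1 gives 76.3%. This is the lower of the two numbers obtained so far, yet its only companion, compound 2 `CN(Cc1ccncc1)C(=S)SCc1ccc(C(=O)Nc2ccccc2N)cc1`, gives in this assay a value of 86.1%, and the two values fall within the scatter of each other, so no order between them can be claimed. For the measured compounds named here, no two measured compounds differ in a single place, so the weight of any one change is not known here.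

Compound 3 `Nc1ccccc1NC(=O)c1ccc(CSC(=S)N2CCN(c3ccncc3)CC2)cc1` has not been measured. It differs from compound 1 by pyridin-4-yl in place of 4-fluorophenyl on an amine nitrogen in a ring. With no comparable single change among the measured compounds, the writer expects the step of a number 1.7 percentage points higher from compound 1 to compound 3 (within the scatter) to stay within the scatter, in no clear direction. Compound 3 is therefore expected to give about 78%, within a range from 60% to 92%.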

Compound 3, a percentage reported as inhibition, at one concentration (the size of the read-out at that concentration, not a potency): 90.7%
For compound 3 the middle estimate is 12.7 percentage points below the measured one; low and high end bracket the measured number.
By their numbers in this assay, from the lowest: compounds 1, 2 and 3 (each within the scatter of the next, the first and the last beyond it).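

In this assay, the exchange of 4-fluorophenyl for pyridin-4-yl on the amine nitrogen of the six-membered non-aromatic ring gives a modest step, a number 14.4 percentage points higher from compound 1 to compound 3 (beyond the scatter). For the compounds shown here, this is the first comparison in which only one place differs, and it shows that the read-out at this single concentration responds to the group held at this position, with the ring bearing a hetero atom giving the higher number on the shared core. The data offer no measured explanation for the step.

From the compounds shown here alone, the exchange removes the fluorine and adds a ring nitrogen in one move, so the share of each in the step stays open. A plain phenyl or a pyridin-3-yl at the same place would be needed to separate them.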